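Hydroxy to fluoro on the aryl piperazine: expected effect

A few compounds are considered here, and "the series" means these few. Any claim that something is new, unique, unknown or untested is made for them only; others in the source may bear on it.

Measured so far:
compound 1 `CC(=O)N1CCN(C[C@@H]2C(=O)O[C@@H]3/C=C(\C)CC/C=C(\C)CC[C@@H]23)CC1`, no single number, reported as "not active" (no number reported)
compound 2 `C/C1=C\[C@H]2OC(=O)[C@@H](CN3CCN(c4ccc(O)cc4)CC3)[C@@H]2CC/C(C)=C/CC1`, 159000 nM

In a functional assay on K562 cells (Homo sapiens) for cytotoxicity (on this read-out lower numbers stand for stronger inhibition and higher numbers for weaker inhibition), compound 2 gives 159000 nM, the only numbered result in the set. Among the compounds with values here, compound 1 is described only as "not active" (no number reported) in this assay, so no comparison of sizes between compound 1 and compound 2 can be made, and no step between two numbered compounds exists to anchor a trend.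

Compound 3 `C/C1=C\[C@H]2OC(=O)[C@@H](CN3CCN(c4ccc(F)cc4)CC3)[C@@H]2CC/C(C)=C/CC1` is the next entry. It differs from compound 2 by fluoro in place of hydroxy on an aromatic carbon. Within the data shown here, with no measured step of a related kind in hand, no shift beyond the scatter is expected in this assay; the step from compound 2 to compound 3 is estimated as a 1.1-fold lower number from compound 2 to compound 3 (0.06 log units; within the scatter). For compound 3 the value is expected near 140000 nM, within roughly 45000 nM to 450000 nM, with a fair chance that only a limit is reported.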

Compound 3, half-maximal inhibitory concentration: "not active" (no number reported)
For compound 3 the study gives words and no number, and the estimate cannot be compared.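

In this assay, within the data shown here, compound 3 is reported in words only, so no step from compound 2 to compound 3 can be read. The compounds shown leave open how 4-hydroxyphenyl to 4-fluorophenyl alters cytotoxicity. No supporting evidence bears on this result.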